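A few compounds are considered here, and "the series" means these few. Any claim that something is new, unique, unknown or untested is made for them only; others in the source may bear on it.

Measured compounds:
Compound 1 `Fc1ccc(C2(c3ccc(F)cc3)CNC(c3cccc(F)c3)=N2)cc1` — 10 nM
Compound 2 `OCc1cccc(C2=NC(c3ccc(F)cc3)(c3ccc(F)cc3)CN2)c1` — 59 nM

In an assay on LM cells for displacement of a labelled ligand from Neuropeptide Y receptor type 5 (Homo sapiens) (on this read-out lower numbers stand for stronger inhibition and higher numbers for weaker inhibition), compound 2 gives 59 nM, the highest of the two numbers shown; compound 1 gives 10 nM, which is a 5.9-fold higher number from compound 1 to compound 2 (0.77 log units; beyond the scatter) when traced toward compound 2. Compound 3 `Fc1ccc(C2(c3ccc(F)cc3)CNC(c3ccccn3)=N2)cc1` has not yet been measured. It differs from compound 2 by pyridin-2-yl in place of 3-(hydroxymethyl)phenyl on a carbon with a double bond to nitrogen. Among the measured compounds shown here, the only measured step, a 5.9-fold higher number from compound 1 to compound 2 (0.77 log units; beyond the scatter), bears on this change indirectly: it shows that the hydroxymethyl-bearing ring of compound 2 sits at a weaker number than the fluoro-bearing ring of compound 1. Compound 3 removes that hydroxymethyl and introduces a ring with one hetero atom instead, so a step back toward the number of compound 1 is expected, though its exact size is uncertain. The estimate for compound 3 is 20 nM with a range of 6 nM to 70 nM, which means an expected 3.0-fold lower number from compound 2 to compound 3 (0.47 log units; beyond the scatter).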

Compound 3, half-maximal inhibitory concentration: 160 nM
Compound 3: middle estimate off by 8.0-fold (0.90 log units), on the low side, outside the stated range (above it).
By their numbers in this assay, from the lowest: compound 1; then compound 2; then compound 3.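

In this assay, the ring at this position matters beyond the hydroxymethyl group: replacing 3-(hydroxymethyl)phenyl with pyridin-2-yl gives a 2.7-fold higher number from compound 2 to compound 3 (0.43 log units; beyond the scatter) and does not bring the number back toward that of compound 1. Set against 3-fluorophenyl, the same pyridin-2-yl gives a 16-fold higher number from compound 1 to compound 3 (1.20 log units; beyond the scatter) and is the largest step among the compounds shown. Among the compounds shown here, of these three rings on the carbon with a double bond to nitrogen, pyridin-2-yl therefore carries the highest number, which the single earlier step could not show. Nothing available explains these steps.

The compounds shown cannot separate the effect of the ring nitrogen from that of losing the substituent on the ring, a question that plain phenyl would address. They also leave open where pyridin-3-yl or 3-methoxyphenyl would fall at this position.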